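Notes on the aryl group at the ring nitrogen

The source may hold more compounds than are shown below. What is called first, only, known or untested is meant among the compounds shown, and "the series" means these compounds.

Compound 1 `O=C(Nc1ccc(Oc2ccnc3[nH]ccc23)cc1)c1cc2cccnc2n(-c2ccccc2)c1=O` gives 360 nM in a functional assay on A549 cells (Homo sapiens) for antiproliferative activity, read by MTT assay, with a stated time of 72 h; a lower number here means a stronger inhibitor, a higher number a weaker inhibitor. Compound 2 `O=C(Nc1ccc(Oc2ccnc3[nH]ccc23)cc1)c1cc2cccnc2n(-c2ccc(F)cc2)c1=O` carries fluoro in place of hydrogen on the aryl ring at the ring nitrogen and in this assay gives 210 nM; the step is a 1.7-fold lower number from compound 1 to compound 2 (0.23 log units; within the scatter). Compound 3 `Cn1ccc2c(Oc3ccc(NC(=O)c4cc5cccnc5n(-c5ccc(F)cc5)c4=O)cc3)ccnc21` carries methyl in place of hydrogen on an aromatic nitrogen and in this assay gives 210 nM; the step is no change at the digits printed from compound 2 to compound 3 (within the scatter). Compound 3 thus stands level with compound 2 at the digits shown, and its gap to compound 1 also lies within the scatter, so the three numbers are not separated.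

Compound 4 `Cn1ccc2c(Oc3ccc(NC(=O)c4cc5cccnc5n(-c5ccc(C(F)(F)F)cc5Cl)c4=O)cc3)ccnc21` differs from compound 3 by 2-chloro-4-(trifluoromethyl)phenyl in place of 4-fluorophenyl on an aromatic nitrogen. Among the measured compounds shown here, the only measured step touching this aryl ring is a 1.7-fold lower number from compound 1 to compound 2 (0.23 log units; within the scatter), which stayed within the scatter; no measured pair covers chloro or trifluoromethyl on this ring. The expected step in this assay is therefore small, a 1.2-fold lower number from compound 3 to compound 4 (0.09 log units; within the scatter), with no firm direction. Compound 4 is estimated at 170 nM, in a range from 70 nM to 450 nM.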

Compound 4, half-maximal inhibitory concentration: 8250 nM
The estimate for compound 4 lay 49-fold (1.69 log units) below the measured number; measured number outside the range, above it.
By their numbers in this assay, from the lowest: compounds 2, 3 and 1 (each within the scatter of the next); then compound 4.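

The aryl group at the ring nitrogen is not indifferent to substitution in this assay: 2-chloro-4-(trifluoromethyl)phenyl in place of 4-fluorophenyl gives a 39-fold higher number from compound 3 to compound 4 (1.59 log units; beyond the scatter). Among the compounds shown here, the earlier change on this ring, a 1.7-fold lower number from compound 1 to compound 2 (0.23 log units; within the scatter), stayed within the scatter, so the position now shows a step beyond the scatter, and a large one, for the first time. Nothing given here bears on the reason for this step.

Chloro and trifluoromethyl enter together, so the step cannot be divided between them, and it remains open which of the two carries it, or whether only the pair does. Also open, on these data alone, are whether an amine or a methoxy group on this aryl ring stays level with compound 3, and whether the step recurs on the core with the hydrogen on the aromatic nitrogen in place of methyl.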